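A few compounds are considered here, and "the series" means these few. Any claim that something is new, unique, unknown or untested is made for them only; others in the source may bear on it.

In an assay on CHO cells for displacement of a labelled ligand from prostaglandin D2 receptor (Mus musculus), read by scintillation counting, with a stated time of 20 min (on this read-out higher numbers stand for weaker inhibition and lower numbers for stronger inhibition), three compounds have been measured. Compound 1 `Cc1c(CC(=O)O)c2ccccc2n1C(=O)c1ccc(OC[C@@H]2CN(C)c3ccccc3O2)cc1` gives 7.7 nM in this assay. Compound 2 `Cc1cc(C(=O)n2c(C)c(CC(=O)O)c3ccccc32)c(C)cc1OC[C@@H]1CN(C)c2ccccc2O1` gives 360 nM. Compound 3 `Cc1cc(OC[C@@H]2CN(C)c3ccccc3O2)ccc1C(=O)n1c(C)c(CC(=O)O)c2cc(F)ccc21` gives 2.7 nM, the lowest of the three numbers; compound 1 lies above it by a gap beyond the scatter, and compound 2 by a much wider gap, also beyond the scatter.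

Compound 4 `Cc1c(CC(=O)O)c2cc(F)ccc2n1C(=O)c1ccc(OC[C@@H]2CN(C)c3ccccc3O2)cc1Cl` has not yet been measured. It differs from compound 3 in one place: chloro in place of methyl on an aromatic carbon of a six-membered aromatic ring of carbon only, ortho to a large group and meta to a large group. Among the compounds with values here, no measured pair among the three compounds shows this exchange, so the size of the step must be estimated from the change alone. The step of a 1.3-fold higher number from compound 3 to compound 4 (0.11 log units; within the scatter) is expected to be small, with no direction that rises beyond the scatter. Compound 4 is accordingly expected to give 3.5 nM in this assay, with a likely range from 1.2 nM to 11 nM.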

Compound 4, inhibition constant: 5.2 nM
For compound 4 the middle estimate is 1.5-fold (0.17 log units) below the measured one; measured number inside the range.
By their numbers in this assay, from the lowest: compounds 3, 4 and 1 (each within the scatter of the next, the first and the last beyond it); then compound 2.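

In this assay, chloro in place of methyl on an aromatic carbon, ortho to a large group and meta to a large group, gives a 1.9-fold higher number from compound 3 to compound 4 (0.28 log units; within the scatter), so at this position the two groups cannot be told apart on this read-out. Within the data shown here, this is the first pair in the set that differs in one place, and it gives the first direct reading of this position: an exchange of one heavy atom for another, with no hydrogen-bond donors or acceptors and no net charge on either side. Nothing measured here offers a reason for this result.

As far as these compounds go, whether a methoxy or a trifluoromethyl group on the same carbon would also stay within the scatter remains open. So does whether this exchange would read the same way on the core of compound 1.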